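A few compounds are considered here, and "the series" means these few. Any claim that something is new, unique, unknown or untested is made for them only; others in the source may bear on it.

In an ADME assay (liver) for metabolic stability, with Liver microsome (Rattus norvegicus) as the target, read by LC-MS, using microsomes and NADPH, with stated times of 5 min and 60 min, tested at 4 uM (on this read-out higher numbers stand for a more stable compound and lower numbers for a less stable compound), the measured compounds give these values
Compound 1 `Cc1c(OCCCCOCOc2ccc(C(=O)O)cc2)ccc(C(=O)CC2CCCC2)c1O` gives 31%
Compound 2 `Cc1c(OCCCCOc2ccc(C(=O)O)cc2F)ccc(C(=O)CC2CCCC2)c1O` gives 66%
Compound 3 `Cc1ccc(C(=O)O)cc1OCCCCOc1ccc(C(=O)CC2CCCC2)c(O)c1C` gives 9%

Compound 3 stands lowest of the three at 9% and is the starting point here. Compound 4 `Cc1c(OCCCCOc2ccc(C(=O)O)c(Cl)c2)ccc(C(=O)CC2CCCC2)c1O` differs from it in one place 4-carboxy-3-chlorophenyl in place of 5-carboxy-2-methylphenyl on an oxygen on a saturated carbon with 4-carboxy-3-chlorophenyl in place of 5-carboxy-2-methylphenyl on an oxygen on a saturated carbon. Two measured steps end at the group that leaves: a number 57 percentage points lower from compound 2 to compound 3 (beyond the scatter) is large and a number 22 percentage points lower from compound 1 to compound 3 (beyond the scatter) is modest. Neither tests the entering group directly, although compound 2 also carries a halogen on that ring. A large rise is therefore expected in this assay with an estimated a number 41 percentage points higher from compound 3 to compound 4 (beyond the scatter) as its size. For compound 4 the estimate is 50% with an expected range from 27% to 74% as its bounds.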

Compound 4, percent of the compound remaining: 67%
Compound 4: middle estimate off by 17 percentage points, on the low side, within the range that was stated.
By their numbers in this assay, from the lowest: compound 3; then compound 1; then compounds 2 and 4 (each within the scatter of the next).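

In this assay the change to 4-carboxy-3-chlorophenyl gives a number 58 percentage points higher from compound 3 to compound 4 (beyond the scatter) and a number 36 percentage points higher from compound 1 to compound 4 (beyond the scatter) while a number 1 percentage points higher from compound 2 to compound 4 (within the scatter) puts the two halogen-bearing rings level. The high number at this place therefore no longer rests on the fluorine-bearing ring of compound 2 alone, and compound 3 with its methyl-bearing ring stands well apart from both. Nothing available explains these differences. From the compounds shown here alone, whether a bromine on the same ring would hold this level remains open, as does the effect of a tetrazole in place of the carboxylic acid.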